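Adding a methoxy group to compound 2 and cytotoxicity

The compounds below may be only part of what the source reports. "The series", "measured", "known", "first", "only" and "open" are said of these compounds alone.

Compound 1 `COc1ccc(C(=O)Nc2ccc(Cl)cc2F)c(O)c1` gives 32300 nM in an ADME assay on RAW264.7 cells (Mus musculus) for cytotoxicity, read by MTT assay, with a stated time of 24 h; on this read-out lower numbers stand for higher toxicity in this test and higher numbers for lower toxicity in this test. Compound 2 `O=C(Nc1ccc(I)cc1F)c1ccccc1O` gives 23300 nM in this assay, and compound 2 stands alongside compound 1, the two numbers lying within the scatter of each other. Compound 3 `O=C(Nc1ccc(I)cc1F)c1ccccc1` gives > 40000 nM in this assay, which is a limit of the assay and sits at the limit of > 40000 nM in this assay, at which 1 of the 3 values shown sits. The step of an at least 1.7-fold higher number from compound 2 to compound 3 (0.23 log units; that floor lies within the scatter) therefore cannot be sized beyond its floor. Compound 4 `COc1ccc(C(=O)Nc2ccc(I)cc2F)c(O)c1` differs from compound 2 by methoxy in place of hydrogen on an aromatic carbon. Going by the values given here, no measured step adds a methoxy group, and the step from compound 2 to compound 3 concerns the hydroxy group instead; the only bearing comes from compound 1, which carries the methoxy group with chlorine in place of iodine and gives a number within the scatter of that of compound 2. Compound 4 is therefore expected to show a 1.2-fold higher number from compound 2 to compound 4 (0.08 log units; within the scatter), a step not beyond the scatter. Compound 4 is estimated at 28000 nM, between 14000 nM and 56000 nM.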

Compound 4, half-maximal cytotoxic concentration: 27600 nM
Beside the measured number, compound 4's estimate is 1.0-fold (0.01 log units) above it; the range from low to high includes it.
By their numbers in this assay, from the lowest: compounds 2, 4 and 1 (each within the scatter of the next). At a limit, above all of these: compound 3.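

In this assay the methoxy group, on an aromatic carbon meta to a hydroxy group and para to a large group, now has a direct step of its own: a 1.2-fold higher number from compound 2 to compound 4 (0.07 log units; within the scatter), so this change at this position stays within the scatter. The halogen also gains a direct step, a 1.2-fold lower number from compound 1 to compound 4 (0.07 log units; within the scatter), which likewise stays within the scatter, whereas compound 1 and compound 2 differ in two places and could not separate the two changes. Nothing shown bears on a cause for either step.

From the compounds shown here alone, whether another group at this position, such as an amine, a carboxylic acid or a longer chain, would give a step beyond the scatter remains open. Going by these compounds, the full size of the step on losing the hydroxy group also remains open, as the value of compound 3 is a limit of the assay.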